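Adding a methyl to compound 2: what to expect

The compounds below may be only part of what the source reports. "The series", "measured", "known", "first", "only" and "open" are said of these compounds alone.

Measured in a functional assay on Bel-7402 cells (Homo sapiens) for inhibition, read by MTT assay, with a stated time of 24 h, tested at 0.1 ug/mL; a lower number here means less inhibition of growth, a higher number more inhibition of growth at the concentration tested:
- compound 1 `O=C(CCCCC(S)CCS)NO` gives 5.96%
- compound 2 `O=C(CCCCC(S)CCS)Nc1ccccc1` gives 0.85%
- compound 3 `O=C(CCCCC(S)CCS)Nc1ccccc1Cl` gives 5.11%

All three numbers are small and lie within the scatter of one another, so compound 2, at 0.85%, cannot be placed apart from compound 1 or compound 3 in this assay. The next compound is compound 4 `Cc1cccc(NC(=O)CCCCC(S)CCS)c1`, and the change is methyl in place of hydrogen on an aromatic carbon, which is methyl in place of hydrogen on an aromatic carbon. The closest measured change is a number 4.3 percentage points higher from compound 2 to compound 3 (within the scatter), which puts chloro in place of hydrogen on an aromatic carbon. The other measured step, a number 5.1 percentage points lower from compound 1 to compound 2 (within the scatter), concerns a different site, phenyl in place of hydroxy on an amide-type nitrogen, and bears on this change only weakly. Within the data shown here, no measured compound carries the methyl itself. Neither step leaves the scatter, so the expected a number 2.2 percentage points higher from compound 2 to compound 4 (within the scatter) is no change beyond the scatter. For compound 4 the estimated value is 3%, with an expected range from 0% to 10%.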

Compound 4, percent growth inhibition at one concentration: 10.1%
The estimate for compound 4 lay 7.1 percentage points below the measured number; the whole stated range lies below it.
By their numbers in this assay, from the lowest: compounds 2, 3, 1 and 4 (each within the scatter of the next).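

In this assay, a methyl in place of hydrogen on an aromatic carbon, meta to a large group, gives a number 9.3 percentage points higher from compound 2 to compound 4 (within the scatter) and so does not set the methyl apart from hydrogen at this place. Among these compounds, this is the first reading for a methyl on the ring, and it adds only one carbon to the phenyl amide without moving the result outside the scatter. Nothing available explains where this number stands.

From the compounds shown here alone, it remains open whether an ethyl, a methoxy or an amine at this same place would give a step beyond the scatter. Going by these compounds, it also remains open whether a methyl on another aromatic carbon of the ring would read the same way in this assay at the single concentration tested.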